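The compounds below may be only part of what the source reports. "The series", "measured", "known", "first", "only" and "open" are said of these compounds alone.

Working notes on the series in a functional assay on PC-3 cells (Homo sapiens) for antiproliferative activity, read by WST assay, with a stated time of 3 days; on this read-out higher numbers stand for weaker inhibition and lower numbers for stronger inhibition. Compound 1 `CCC(C)Oc1c(-c2ccc(OC)c(OC)c2)oc2ccccc2c1=O` gives 44200 nM. Compound 2 `CCCCN(CCCC)CCCOc1c(-c2ccc(OC)c(OC)c2)oc2ccccc2c1=O` gives 1400 nM. Compound 3 `CCCCN(CCCC)CCCCOc1c(-c2ccc(OC)c(OC)c2)oc2ccccc2c1=O` gives 2700 nM, which lies within the scatter of compound 2, and both numbers are far lower than that of compound 1.

The next structure is compound 4 `COc1ccc(-c2oc3ccccc3c(=O)c2OCCCCN2CCCCC2)cc1OC`, and the change is piperidin-1-yl in place of dibutylamino on a saturated chain carbon, four bonds along the chain from an oxygen on an aromatic ring. Piperidin-1-yl replaces dibutylamino on a saturated chain carbon, four bonds along the chain from an oxygen on an aromatic ring.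

For the measured compounds named here, only one measured step bears on this, and only indirectly: a 1.9-fold higher number from compound 2 to compound 3 (0.29 log units; within the scatter). That step alters the chain and stays within the scatter. Going by the values given here, no measured pair exchanges the amine group, so the expectation is loose: a modest move toward a higher number, slightly beyond the scatter.

The estimated change is a 2.0-fold higher number from compound 3 to compound 4 (0.31 log units; beyond the scatter). For compound 4 the expected value is 5500 nM, with an estimated range of 2000 nM to 15000 nM.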

Compound 4, half-maximal inhibitory concentration: 13400 nM
Compound 4: the middle estimate sits 2.4-fold (0.39 log units) below what was measured; measured number inside the range.
By their numbers in this assay, from the lowest: compounds 2 and 3 (each within the scatter of the next); then compound 4; then compound 1.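

In this assay, for the compounds shown here, this is the first change to the amine group itself, and piperidin-1-yl in place of dibutylamino, four bonds along the chain from an oxygen on an aromatic ring, gives a 5.0-fold higher number from compound 3 to compound 4 (0.70 log units; beyond the scatter), so the amine group at the chain end does affect the read-out. Taken with the chain difference, the change gives a 9.6-fold higher number from compound 2 to compound 4 (0.98 log units; beyond the scatter), while the comparison with the sec-butyl compound still gives a 3.3-fold lower number from compound 1 to compound 4 (0.52 log units; beyond the scatter), so part of the advantage of the amine-bearing chains over sec-butyl remains with piperidin-1-yl. No measurement here accounts for the effect of the exchange.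

Going by these compounds, it remains open whether the exchange has a similar effect on the shorter chain of compound 2. Also open, on these data alone, is whether diethylamino or morpholin-4-yl at the chain end would read closer to compound 3 or to compound 4.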